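This account rests on a few compounds, and the source may have more. Where it says the series, first, only, none or still open, it means among the compounds named here.

Compound 3 `COc1cc(OC)c2c(=O)cc(C(=O)Nc3ccc(Oc4ccc([N+](=O)[O-])cc4)cc3)[nH]c2c1` was tested in a functional assay on HepG2 cells (Homo sapiens) for antiproliferative activity, with a stated time of 72 h (on this read-out higher numbers stand for an effect only at larger amounts of compound and lower numbers for an effect already at smaller amounts), and for it only a limit is known: in this assay compound 3 gives > 22900 nM, which is a limit and not a number. Its two neighbours stand the same way. Compound 1 `COC(=O)c1cc(=O)c2c(OC)cc(OC)cc2[nH]1`, the small shared core with a methyl ester, gives > 34400 nM in this assay, again a limit. Compound 2 `COc1cc(OC)c2c(=O)cc(C(=O)Nc3ccc(C4CCCCC4)cc3)[nH]c2c1`, which carries a cyclohexyl on the amide ring, gives > 43100 nM in this assay, also a limit. The step that the two limits leave unreadable from compound 2 to compound 3 is therefore one that the two limits leave unreadable.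

Compound 4 `COc1cc(OC)c2c(=O)cc(C(=O)Nc3ccc(Oc4cccnc4)cc3)[nH]c2c1` has not yet been measured. It differs from compound 3 in one place: pyridin-3-yl in place of 4-nitrophenyl on an oxygen on an aromatic ring. Among the measured compounds shown here, no measured step bears directly on this change, and the only step, from a cyclohexyl to a 4-nitrophenoxy, was itself unreadable, with all three values sitting at limits (the limit of > 22900 nM in this assay, at which 1 of the 3 values shown sits, (the limit of > 34400 nM in this assay, at which 1 of the 3 values shown sits), (the limit of > 43100 nM in this assay, at which 1 of the 3 values shown sits)). The expectation is therefore that compound 4 behaves like compound 3, with a step that the limit leaves unreadable from compound 3 to compound 4 that is not beyond the scatter. Compound 4 is estimated at 30000 nM in this assay, within a range from 8000 nM to 100000 nM, and most likely again reported only as a limit.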

Compound 4, half-maximal effective concentration: > 32100 nM
Compound 4: no number, only a limit; the forecaster's own chance of this, stated with the estimate: 80%; middle value at least 1.0-fold (0.02 log units) from the limit.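

In this assay compound 4 gives > 32100 nM, which is a limit and not a number. The steps joining compound 4 to compound 3 and to compound 2 link only limits and cannot be read. The compounds shown leave open what amount of any of them gives an effect in this assay, and whether exchanging the group on the oxygen changes that amount.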